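Adding fluorine to an efficacious fatty acid receptor agonist

The source may report more compounds than this note shows. Statements on the series, on what has been measured and on what is new or still open speak of the compounds shown alone.

Two compounds share a core and differ at a single spot. Compound 1 `Cc1nn(-c2ccccn2)c2cc(-c3ccc(CCC(=O)O)cc3)ccc12` carries a methyl group on an aromatic carbon of that core; in a functional assay on cells for agonist activity at Free fatty acid receptor 1 (Mus musculus), read by FLIPR and calcium flux, with a stated time of 5 min (on this read-out higher numbers stand for larger maximal responses and lower numbers for smaller maximal responses), compound 1 reaches 95%. Compound 2 `O=C(O)CCc1ccc(-c2ccc3cnn(-c4ccccn4)c3c2)cc1` has a hydrogen in that position instead, and in this assay compound 2 reaches 106%. Among the compounds with values here, the only measured step, a number 11 percentage points higher from compound 1 to compound 2 (beyond the scatter), comes from exchanging hydrogen for methyl on an aromatic carbon. Among the two numbers known, compound 2 holds the higher one, with compound 1 below it by a margin beyond the scatter.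

Compound 3 `O=C(O)CCc1ccc(-c2cc(F)c3cnn(-c4ccccn4)c3c2)cc1` is not yet measured. Its change from compound 2 is fluoro in place of hydrogen on an aromatic carbon. Within the data shown here, no measured step concerns a fluorine entering the core; the step from compound 1 to compound 2 swaps a methyl for a hydrogen at a different aromatic carbon and is the only guide to how tolerant the maximal response is to small changes on this core. Since that step was modest, the expected step of a number 6 percentage points lower from compound 2 to compound 3 (within the scatter) is small, with no direction firmly indicated. The estimated value for compound 3 in this assay is 100%, within 85% to 115%.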

Compound 3, largest response reached (reported as efficacy), in percent of the reference or control that the assay uses: 126%
Estimate against measurement, compound 3: 26 percentage points below; the whole stated range lies below it.
By their numbers in this assay, from the lowest: compound 1; then compound 2; then compound 3.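

In this assay, the fluoro group gives a number 20 percentage points higher from compound 2 to compound 3 (beyond the scatter), so this aromatic carbon of the shared core tolerates a fluorine and the maximal response rises beyond the scatter. Within the data shown here, the earlier pair concerned only a methyl and a hydrogen at a different aromatic carbon, so this is the first sign that this position can also change the maximal response, with a single heavy atom that adds no ring, no net charge and no hydrogen-bond donors or acceptors. Nothing measured here accounts for the rise, and its cause remains unknown.

The compounds shown leave open whether the higher response is particular to fluorine or would also appear with another group on this carbon, such as chloro, methoxy or nitrile. They also leave open whether a fluoro group on other aromatic carbons of the core would give a similar step, and how this change affects any read-out other than the largest response.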